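Notes on a chloro addition at the benzylsulfanyl arm

The compounds below may be only part of what the source reports. "The series", "measured", "known", "first", "only" and "open" are said of these compounds alone.

Compound 1, `CC1=C(C(=O)Nc2ccc(F)cc2)C(c2ccc([N+](=O)[O-])cc2)N=C(SCc2ccccc2Cl)N1`: 17.4%
Compound 2, `CC1=C(C(=O)Nc2ccc(Br)cc2)C(c2ccc(Cl)cc2Cl)N=C(SCc2ccccc2)N1`: 17.4%

In a functional assay on the whole organism (artery, strain albino) with Rattus norvegicus as the target, with a stated time of 600 min, at a dose of 10 mg/kg by the oral route (on this read-out lower numbers stand for less inhibition and higher numbers for more inhibition at the one dose given (going by the name of the read-out)), compound 1 gives 17.4%. Compound 2 gives 17.4% in this assay, level with compound 1 at the digits shown and within the scatter. Compound 3, `CC1=C(C(=O)Nc2ccc(Br)cc2)C(c2ccc(Cl)cc2Cl)N=C(SCc2ccccc2Cl)N1`, is not yet measured. It differs from compound 2 by chloro in place of hydrogen on an aromatic carbon. Going by the values given here, no measured pair covers this change directly. The expectation rests on compound 1 at 17.4%, which already carries the 2-chlorobenzyl arm and stands level with compound 2. The step from compound 2 to compound 3 is therefore expected to be a number 0.6 percentage points higher from compound 2 to compound 3 (within the scatter), nothing beyond the scatter. Compound 3 is estimated at 18% in this assay, within 8% to 30%.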

Compound 3, a percentage reported as inhibition, in the whole organism at one dose (the size of the read-out at that dose, not a potency): 24.6%
Compound 3: the middle estimate sits 6.6 percentage points below what was measured; the range from low to high includes it.
By their numbers in this assay, from the lowest: compounds 1, 2 and 3 (each within the scatter of the next).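

In this assay, going by these compounds alone, the change from benzyl to 2-chlorobenzyl gives the first direct reading at this position, a number 7.2 percentage points higher from compound 2 to compound 3 (within the scatter). At this one dose, chloro on this aromatic carbon therefore brings no change beyond the scatter on the background of compound 2. No measurement available here bears on this step. As far as these compounds go, it remains open whether an amine, a methoxy group or a carboxylic acid at this place would shift the read-out beyond the scatter. From the compounds shown here alone, the size of the step at other doses also remains open.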